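Butoxy to diethylamino on the shared core

The compounds below may be only part of what the source reports. "The series", "measured", "known", "first", "only" and "open" are said of these compounds alone.

In an ADME assay on L6 cells (Rattus norvegicus) for cytotoxicity, read by resazurin assay, with a stated time of 72 h (a higher number here means a weaker inhibitor, a lower number a stronger inhibitor), compound 3 `CCCCOc1ccc(C(=O)NC(=O)c2ccccc2O)cc1` gives 13 ug/mL, the lowest number of the three measured and beyond the scatter from both others. Compound 1 `O=C(NC(=O)c1ccccc1O)c1ccc(F)cc1` gives 38 ug/mL and compound 2 `COC(=O)c1ccc(C(=O)NC(=O)c2ccccc2O)cc1` gives 42 ug/mL, and these two do not separate, with a 1.1-fold higher number from compound 1 to compound 2 (0.04 log units; within the scatter).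

Compound 4 `CCN(CC)c1ccc(C(=O)NC(=O)c2ccccc2O)cc1` carries diethylamino in place of butoxy on an aromatic carbon, para to a large group: diethylamino in place of butoxy on an aromatic carbon.

Within the data shown here, two measured steps bear on this change, both modest and both ending at butoxy: a 2.9-fold lower number from compound 1 to compound 3 (0.47 log units; beyond the scatter) and a 3.2-fold lower number from compound 2 to compound 3 (0.51 log units; beyond the scatter). Among the measured compounds shown here, neither replaces butoxy with diethylamino, and no measured compound carries diethylamino, so the data give no direct guide. The two groups match in the counts above, and the modest size of a 2.9-fold lower number from compound 1 to compound 3 (0.47 log units; beyond the scatter) argues against expecting a large move in this assay. The expected change is a 1.2-fold higher number from compound 3 to compound 4 (0.09 log units; within the scatter), which is no step beyond the scatter. For compound 4 the estimated value is 16 ug/mL, with an expected range of 7 ug/mL to 35 ug/mL.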

Compound 4, half-maximal inhibitory concentration: 8.2 ug/mL
For compound 4 the middle estimate is 2.0-fold (0.29 log units) above the measured one; low and high end bracket the measured number.
By their numbers in this assay, from the lowest: compounds 4 and 3 (each within the scatter of the next); then compounds 1 and 2 (each within the scatter of the next).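

In this assay, diethylamino in place of butoxy on this aromatic carbon gives a 1.6-fold lower number from compound 3 to compound 4 (0.20 log units; within the scatter) and so leaves the two groups unseparated at this position. Diethylamino also stands apart from both other groups, with a 4.6-fold lower number from compound 1 to compound 4 (0.67 log units; beyond the scatter) and a 5.1-fold lower number from compound 2 to compound 4 (0.71 log units; beyond the scatter) as modest steps, so the four compounds now fall into a lower pair carrying butoxy or diethylamino and a higher pair carrying fluoro or methoxycarbonyl. No supporting measurement on hand accounts for this split.

Still open, as far as these compounds go, is whether methoxy, a longer chain such as hexyloxy, or a cyclic amine such as morpholine would join the lower pair. A carboxylic acid at the same place would test whether the higher pair extends beyond fluoro and methoxycarbonyl.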